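Working notes: extending the butyl chain of compound 1

The compounds below may be only part of what the source reports. "The series", "measured", "known", "first", "only" and "open" are said of these compounds alone.

Measured so far:
compound 1 `CCCCn1nc(-c2cccnc2)c2ccccc2c1=O` – 91%
compound 2 `O=c1c2ccccc2c(-c2cccnc2)nn1C1CCCC1` – 97%

In an assay on isolated protein (Oryctolagus cuniculus) with Thromboxane-A synthase (Homo sapiens) as the target, tested at 1 uM (a higher number here means more inhibition at the concentration tested (going by the name of the read-out), a lower number less inhibition), compound 1 gives 91%, the lower of the two numbers measured, while compound 2 gives 97%; the step of a number 6 percentage points higher from compound 1 to compound 2 (within the scatter) lies within the scatter. Compound 3 `O=c1c2ccccc2c(-c2cccnc2)nn1CCCCSc1ncccn1` differs from compound 1 by (pyrimidin-2-yl)sulfanyl in place of hydrogen on a saturated chain carbon, four bonds along the chain from an aromatic nitrogen. Going by the values given here, no measured step touches the far end of that chain; the only measured step, cyclopentyl in place of butyl, shows that varying the group on the aromatic nitrogen leaves this assay unchanged beyond the scatter. No step beyond the scatter is therefore expected here. Compound 3 is expected to give 90% (range 75% to 98%). That estimate means an expected step of a number 1 percentage points lower from compound 1 to compound 3 (within the scatter).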

Compound 3, a percentage reported as inhibition, at one concentration (the size of the read-out at that concentration, not a potency): 96%
The estimate for compound 3 lay 6 percentage points below the measured number, within the range that was stated.
By their numbers in this assay, from the lowest: compounds 1, 3 and 2 (each within the scatter of the next).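

In this assay, (pyrimidin-2-yl)sulfanyl in place of hydrogen on a saturated chain carbon, four bonds along the chain from an aromatic nitrogen, gives a number 5 percentage points higher from compound 1 to compound 3 (within the scatter). The chain carbon therefore carries this sulfur-linked aromatic ring without a step beyond the scatter, which the cyclopentyl step could not show. No supporting measurement bears on this result.

On these data alone, whether an amine, a carboxylic acid or a longer chain at this carbon would keep the read-out in this range remains open. So does the effect of an oxygen in place of the sulfur link.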